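This account rests on a few compounds, and the source may have more. Where it says the series, first, only, none or still open, it means among the compounds named here.

Three close relatives share one core and have been measured in an ADME assay on liver for metabolic stability, with Liver microsome (Homo sapiens) as the target, read by LC-MS, using microsomes; on this read-out higher numbers stand for fast clearance and lower numbers for slow clearance. Compound 1, `COC(C)(C)[C@@H](O)C(=O)N1[C@H](C(=O)NCc2cc(Cl)ccc2-n2cnnn2)C[C@@H]2C[C@@H]21`, gives 40 mL.min-1.g-1 in this assay, the highest of the three numbers. Compound 2, `O=C(NCc1cc(Cl)ccc1-n1cnnn1)[C@@H]1C[C@H]2C[C@H]2N1C(=O)[C@H](O)c1cccc(F)c1`, gives 32 mL.min-1.g-1, and compound 3, `CC(C)(C)C[C@@H](O)C(=O)N1C[C@@H]2C[C@@H]2[C@H]1C(=O)NCc1cc(Cl)ccc1-n1cnnn1`, gives 20 mL.min-1.g-1. The gaps from compound 1 to compound 2 and from compound 1 to compound 3 both lie within the usual scatter of repeated measurements, so the three compounds cannot be separated on these numbers.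

Compound 4, `O=C(NCc1cc(Cl)ccc1-n1cnnn1)[C@@H]1C[C@@H]2C[C@@H]2N1C(=O)[C@H](O)C1CCCCC1`, has not yet been measured. It differs from compound 1 in one place: cyclohexyl in place of 1-methoxy-1-methylethyl on a saturated chain carbon bound to a carbonyl carbon and an oxygen on a saturated carbon. Compound 3 carries a different saturated chain at the same place and gives 20 mL.min-1.g-1, which is the only hint available.

For the measured compounds named here, no two measured compounds differ in exactly this way, so the step has to be estimated. The step is expected to be small, a 1.3-fold lower number from compound 1 to compound 4 (0.12 log units; within the scatter), and not beyond the scatter in either direction. Compound 4 is therefore expected to give about 30 mL.min-1.g-1 in this assay, with a range from 12 mL.min-1.g-1 to 75 mL.min-1.g-1.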

Compound 4, intrinsic clearance in microsomes: 150 mL.min-1.g-1
Compound 4: the middle estimate sits 5.0-fold (0.70 log units) below what was measured; measured number above the stated range.
By their numbers in this assay, from the lowest: compounds 3, 2 and 1 (each within the scatter of the next); then compound 4.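

In this assay, for the compounds shown here, the place on a saturated chain carbon bound to a carbonyl carbon and an oxygen on a saturated carbon proves sensitive to what it carries: cyclohexyl in place of 1-methoxy-1-methylethyl gives a 3.8-fold higher number from compound 1 to compound 4 (0.57 log units; beyond the scatter), a step beyond the scatter, while the earlier compounds could not be separated. This single change removes the hydrogen-bond acceptor of the leaving group and brings in a six-membered ring of carbon only, so one step cannot show which of these differences matters. No measured evidence here explains the step.

Still open, from the compounds shown here alone, is whether a tetrahydropyranyl group, a six-membered ring holding an oxygen, would give a number closer to compound 1 or to compound 4. Also open, going by these compounds, is whether a cyclohexyl ring carrying a hydroxyl group would do the same.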